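From Benzyl Amide to Fluorinated Anilide

This account rests on a few compounds, and the source may have more. Where it says the series, first, only, none or still open, it means among the compounds named here.

Within the data shown here, in a functional assay on A549 cells (Homo sapiens) for inhibition, read by MTT assay, with a stated time of 48 h (on this read-out lower numbers stand for stronger inhibition and higher numbers for weaker inhibition), compound 2 (`COc1ccc(CNC(=O)/C=C/c2coc3cc(OC)ccc3c2=O)cc1`) gives 22500 nM, the only true number so far. Compound 1 (`COc1ccc2c(=O)c(/C=C/C(=O)NCc3ccccc3F)coc2c1`) reads > 100000 nM, which is a limit. Compound 3 (`COc1ccc2c(=O)c(/C=C/C(=O)Nc3ccc(F)cc3)coc2c1`) carries 4-fluorophenyl in place of 4-methoxybenzyl on an amide-type nitrogen . Among the measured compounds shown here, one measured step bears on this change (an at least 4.4-fold lower number from compound 1 to compound 2 (0.64 log units; beyond the scatter)) , with 4-methoxyphenyl in place of 2-fluorophenyl, and its size is open-ended (the limit of > 100000 nM in this assay, at which 1 of the 2 values shown sits) . Compound 3 also lacks the methoxy-bearing group, so a modest move towards weaker inhibition is expected (a 2.2-fold higher number from compound 2 to compound 3 (0.35 log units; beyond the scatter)) . For compound 3 the estimate is 50000 nM, with an expected range from 15000 nM to 100000 nM.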

Compound 3, half-maximal inhibitory concentration: 26800 nM
For compound 3 the middle estimate is 1.9-fold (0.27 log units) above the measured one; the range from low to high includes it.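

In this assay, 4-fluorophenyl in place of 4-methoxybenzyl on an amide-type nitrogen gives a 1.2-fold higher number from compound 2 to compound 3 (0.08 log units; within the scatter), so this nitrogen can lose both the methoxy group and the saturated chain carbon without a change beyond the scatter. A fluorinated group here also need not read weakly, with an at least 3.7-fold lower number from compound 1 to compound 3 (0.57 log units; beyond the scatter). The size of that second step is open-ended: the limit of > 100000 nM in this assay, at which 1 of the 3 values shown sits.

The compounds shown leave open how 4-fluorobenzyl would read, which would separate the effect of the saturated chain carbon from that of the ring substituent. They also leave open whether a longer chain or a ring carrying an amine would be tolerated on this nitrogen.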